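Trimming the Methyl from a Cyclopropyl Group

The source may hold more compounds than are shown below. What is called first, only, known or untested is meant among the compounds shown, and "the series" means these compounds.

Measured compounds in an assay on HEK293 cells for activation of Kir3.1/Kir3.2 (Homo sapiens), read by thallium flux; on this read-out higher numbers stand for an effect only at larger amounts of compound and lower numbers for an effect already at smaller amounts:
compound 1, `Cc1cc(NC(=O)Cn2nnc(-c3ccccc3)n2)n(C2CCCCC2)n1`: 96 nM
compound 2, `Cc1cc(NC(=S)Cn2nnc(-c3ccccc3)n2)n(C2CCCCC2)n1`: 623 nM
compound 3, `CC1(c2cc(NC(=O)Cn3nnc(-c4ccccc4)n3)n(C3CCCCC3)n2)CC1`: a limit of the assay, > 10000 nM

Compound 3 sits only at a limit, (the limit of > 10000 nM in this assay, at which 1 of the 3 values shown sits), and gives no number in this assay. Compound 4, `O=C(Cn1nnc(-c2ccccc2)n1)Nc1cc(C2CC2)nn1C1CCCCC1`, differs from compound 3 by hydrogen in place of methyl on a saturated ring carbon. For the measured compounds named here, the one measured step that bears on this is an at least 100-fold higher number from compound 1 to compound 3 (2.01 log units; beyond the scatter), where methyl became 1-methylcyclopropyl. Going by the values given here, compound 4 keeps the three-membered ring but drops the methyl, so a partial return toward compound 1 is expected, although no measured pair shows cyclopropyl itself. The step of an at least 6.6-fold lower number from compound 3 to compound 4 (0.82 log units; beyond the scatter) is therefore expected in this assay. Compound 4 is estimated at 1500 nM, within 200 nM to 10000 nM.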

Compound 4, half-maximal effective concentration: 271 nM
For compound 4 the middle estimate is 5.5-fold (0.74 log units) above the measured one, within the range that was stated.
By their numbers in this assay, from the lowest: compound 1; then compound 4; then compound 2. At a limit, above all of these: compound 3.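

In this assay, taking the methyl off the three-membered ring restores most of what 1-methylcyclopropyl lost, with an at least 36-fold lower number from compound 3 to compound 4 (1.56 log units; beyond the scatter). The loss therefore lies largely with that single methyl and not with the ring itself, although cyclopropyl in place of methyl on an aromatic carbon still leaves a modest gap, with a 2.8-fold higher number from compound 1 to compound 4 (0.45 log units; beyond the scatter). Compound 3 stands only at a limit, so the recovery has no exact size: the limit of > 10000 nM in this assay, at which 1 of the 4 values shown sits. The compounds shown leave open where an ethyl, an isopropyl or a cyclobutyl at this position would fall, and how a hydroxymethyl or an amine on the cyclopropyl ring would read.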